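Swapping One Fluorinated Group on the Benzyl Arm

The compounds below may be only part of what the source reports. "The series", "measured", "known", "first", "only" and "open" are said of these compounds alone.

Compound 1 `NS(=O)(=O)c1ccc2c(c1)C(=O)C(=O)N2` gives > 50000 nM (a limit of the assay, not a number)
Compound 2 `NS(=O)(=O)c1ccc2c(c1)C(=O)C(=O)N2Cc1ccc(SC(F)(F)F)cc1` gives 4500 nM

Both results come from a functional assay on K562 cells (Homo sapiens) for inhibition, read by MTT assay, with a stated time of 72 h; on this read-out lower numbers stand for stronger inhibition and higher numbers for weaker inhibition. The entry for compound 1 is only a limit, and it gives no exact value to compare with. Going by the values given here, compound 2 gives 4500 nM as the only true number in the set, so there is no second number against which to rank it.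

Compound 3 `NS(=O)(=O)c1ccc2c(c1)C(=O)C(=O)N2Cc1ccc(C(F)(F)F)cc1` has not yet been measured. It keeps the shared core of compound 1 and differs from compound 2 in one group, with trifluoromethyl in place of (trifluoromethyl)sulfanyl on an aromatic carbon, para to a large group (trifluoromethyl in place of (trifluoromethyl)sulfanyl on an aromatic carbon). Among the compounds with values here, no measured pair shows what this exchange does, so the expectation rests on the small size of the structural change alone. The expected step (a 1.3-fold higher number from compound 2 to compound 3 (0.12 log units; within the scatter)) is estimated to stay within the usual scatter, with any drift more likely towards weaker inhibition than stronger. In this assay the estimate for compound 3 is 6000 nM (expected range 2500 nM to 15000 nM).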

Compound 3, half-maximal inhibitory concentration: 16000 nM
Beside the measured number, compound 3's estimate is 2.7-fold (0.43 log units) below it; the measured number lies above the stated range.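

In this assay, going by these compounds alone, putting trifluoromethyl in place of (trifluoromethyl)sulfanyl gives the first step that can be read in this set: a 3.6-fold higher number from compound 2 to compound 3 (0.55 log units; beyond the scatter). This shows that the place on the aromatic ring of the benzyl arm responds to the exchange of a single group: with the rest of the molecule unchanged, the loss of the sulfur goes with a step beyond the scatter, towards weaker inhibition. Steps from compound 1 cannot be read, since its entry is a limit and not a number: the limit of > 50000 nM in this assay, at which 1 of the 3 values shown sits.

Within the data shown here, what remains open is how far this single step speaks for the place as a whole, as it rests on only one pair of compounds and gives no reason for the rise in the number. A methylsulfanyl group, a methoxy group, a chlorine atom or an amine at the same place would show whether the sulfur, the fluorine atoms or neither of these goes with the stronger inhibition of compound 2.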